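Swapping a Sulfanyl Arm for a Sulfonyl Arm

The source may report more compounds than this note shows. Statements on the series, on what has been measured and on what is new or still open speak of the compounds shown alone.

Compound 2 `CN(C)c1ccc(/C=C(/SCc2ccc(F)cc2)C(=O)c2ccc(Cl)cc2)cc1` stands in a functional assay on DU-145 cells (Homo sapiens) for inhibition, read by trypan blue exclusion, with a stated time of 96 h (a lower number here means a stronger inhibitor of growth, a higher number a weaker inhibitor of growth), at 50000 nM. Going by the values given here, its only measured neighbour, compound 1 `CN(C)c1ccc(/C=C(/SCc2ccc(F)cc2)C(=O)c2ccc(Br)cc2)cc1`, gives 50000 nM in this assay. Among the compounds with values here, the sole measured step, no change at the digits printed from compound 1 to compound 2 (within the scatter), concerns a halogen swap on an aromatic carbon and says nothing about the chain carbon altered next. Compound 3 `CN(C)c1ccc(/C=C(\C(=O)c2ccc(Cl)cc2)S(=O)(=O)c2ccc(Br)cc2)cc1` differs from compound 2 by (4-bromophenyl)sulfonyl in place of (4-fluorobenzyl)sulfanyl on a double-bonded chain carbon bound to a carbonyl carbon and a double-bonded chain carbon. Within the data shown here, no measured step bears on such a change, so neither direction nor size can be drawn from the data, and a step no larger than the scatter is assumed. Compound 3 is therefore expected at 35000 nM, within 8000 nM to 50000 nM, an expected step of a 1.4-fold lower number from compound 2 to compound 3 (0.15 log units; within the scatter).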

Compound 3, concentration for 50% growth inhibition: > 100000 nM
Compound 3 ended at the assay's limit (the forecaster's own chance of this, stated with the estimate: 35%); middle value at least 2.8-fold (0.45 log units) from the limit.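

Compound 3 carries a limit and not a number: the limit of > 100000 nM in this assay, at which 1 of the 3 values shown sits. Going by these compounds alone, replacing (4-fluorobenzyl)sulfanyl with (4-bromophenyl)sulfonyl on a double-bonded chain carbon bound to a carbonyl carbon and a double-bonded chain carbon gives an at least 2.0-fold higher number from compound 2 to compound 3 (0.30 log units; that floor lies within the scatter), the first reading at this position, on which the earlier halogen swap said nothing. This replacement brought no lower number, and the true size of the step stays hidden behind the limit. Still open, going by these compounds, is whether an amine, a carboxylic acid or a longer chain at this carbon would lower the number, and whether the sulfonyl or the bromine of the new arm governs the result.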